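Nitro Substitution on a Weakly Cytotoxic Fused Core

The compounds below may be only part of what the source reports. "The series", "measured", "known", "first", "only" and "open" are said of these compounds alone.

Measured compounds:
compound 1 `O=Cc1c(-c2ccccc2)nc2sc(Cc3ccc(Cl)cc3)nn12` gives 20000 nM in a functional assay on L1210 cells (Mus musculus) for cytotoxicity, with a stated time of 48 h; a lower number here means a stronger inhibitor, a higher number a weaker inhibitor
compound 2 `O=Cc1c(-c2ccc([N+](=O)[O-])cc2)nc2sc(Cc3ccc(Cl)cc3)nn12` gives 15000 nM in this assay
compound 3 `N#CSc1c(-c2ccccc2)nc2sc(Cc3ccc(Cl)cc3)nn12` gives 24000 nM in this assay

For the measured compounds named here, all three numbers lie within the usual scatter of one another, so no compound can be called stronger or weaker than another. Compound 4 `N#CSc1c(-c2ccc([N+](=O)[O-])cc2)nc2sc(Cc3ccc(Cl)cc3)nn12` has not yet been measured. It differs from compound 3 by nitro in place of hydrogen on an aromatic carbon; the same change was made from compound 1 to compound 2, and there it gave a 1.3-fold lower number from compound 1 to compound 2 (0.12 log units; within the scatter). The two cores differ by cyanosulfanyl in place of formyl on an aromatic carbon; that difference gave a 1.2-fold higher number from compound 1 to compound 3 (0.08 log units; within the scatter). The expected step from compound 3 to compound 4 is a 1.3-fold lower number from compound 3 to compound 4 (0.10 log units; within the scatter), resting on the step of a 1.3-fold lower number from compound 1 to compound 2 (0.12 log units; within the scatter) that the same change made on the other core. Compound 4 is therefore estimated at 19000 nM, with a likely range from 8000 nM to 45000 nM.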

Compound 4, half-maximal inhibitory concentration: 50000 nM
Compound 4: middle estimate off by 2.6-fold (0.42 log units), on the low side; the measured number lies above the stated range.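

On the core of compound 3, nitro in place of hydrogen gives a 2.1-fold higher number from compound 3 to compound 4 (0.32 log units; beyond the scatter) in this assay, so the change does not carry over unaltered from the core of compound 1: the same change on two cores in this assay, a 1.3-fold lower number (0.12 log units; within the scatter) from compound 1 to compound 2 and a 2.1-fold higher number (0.32 log units; beyond the scatter) from compound 3 to compound 4, 2.8-fold (0.44 log units) apart, beyond the scatter of two such steps

Read the other way, cyanosulfanyl in place of formyl gives a 3.3-fold higher number from compound 2 to compound 4 (0.52 log units; beyond the scatter), and this step also stands apart from the one on the phenyl compounds: the same change on two cores in this assay, a 1.2-fold higher number (0.08 log units; within the scatter) from compound 1 to compound 3 and a 3.3-fold higher number (0.52 log units; beyond the scatter) from compound 2 to compound 4, 2.8-fold (0.44 log units) apart, beyond the scatter of two such steps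

This shows that, in these four compounds, the result of a change in one place depends on the group in the other, but it rests on a single set of four and does not show the reason.

As far as these compounds go, whether the same dependence would appear with an amine in place of nitro, or with a carboxylic acid in place of formyl, remains open.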